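A few compounds are considered here, and "the series" means these few. Any claim that something is new, unique, unknown or untested is made for them only; others in the source may bear on it.

Notes on the series, all in a functional assay on A549 cells (Homo sapiens) for antiproliferative activity, read by MTT assay; on this read-out lower numbers stand for stronger inhibition and higher numbers for weaker inhibition. Compound 1 (`O=C1NC(c2ccccc2)CN1S(=O)(=O)c1ccc2c(c1)CCCN2`) is reported only as a limit, > 20000 nM. For the measured compounds named here, compound 2 (`CCCOC(=O)N1CCCc2cc(S(=O)(=O)N3CC(c4ccccc4)NC3=O)ccc21`) gives 1030 nM, the only actual number so far.

Compound 3 (`CC(C)COC(=O)N1CCCc2cc(S(=O)(=O)N3CC(c4ccccc4)NC3=O)ccc21`) differs from compound 2 as follows: methyl in place of hydrogen on a saturated chain carbon bound to two saturated chain carbons. In words, this is methyl in place of hydrogen on a saturated chain carbon bound to two saturated chain carbons, or propoxy to isobutoxy.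

Going by the values given here, one measured step bears on this change: propoxycarbonyl in place of hydrogen gave an at least 19-fold lower number from compound 1 to compound 2 (1.28 log units; beyond the scatter), a large step. On these data alone, its true size stays open, given (the limit of > 20000 nM in this assay, at which 1 of the 2 values shown sits). That step adds the whole group, whereas here the group only gains a methyl, and no change within the chain has been measured. A much smaller step is therefore expected, with no firm direction and probably within the scatter. The expected step is a 1.1-fold lower number from compound 2 to compound 3 (0.06 log units; within the scatter). For compound 3 the estimated value is 900 nM, with an expected range of 350 nM to 2400 nM.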

Compound 3, half-maximal inhibitory concentration: > 20000 nM
Compound 3 ended at the assay's limit; the forecaster's own chance of this, stated with the estimate: 3%; middle value at least 22-fold (1.34 log units) away from the limit.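

In this assay, adding a single methyl on a saturated chain carbon bound to two saturated chain carbons, which turns propoxy into isobutoxy, gives an at least 19-fold higher number from compound 2 to compound 3 (1.28 log units; beyond the scatter). The gain seen with propoxycarbonyl therefore does not extend to every alkoxycarbonyl group at this nitrogen: the outcome turns on the chain itself, and even a one-methyl change here can be large, whereas compound 1 and compound 2 alone could not show this. The step between compound 1 and compound 3 cannot be read, and the step to compound 3 has only a lower bound, its full size staying open: the limit of > 20000 nM in this assay, at which 2 of the 3 values shown sit.

On these data alone, whether the loss goes with the branch or with the added carbon stays open, and a straight butoxycarbonyl group would separate the two. As far as these compounds go, how a shorter ethoxycarbonyl group behaves at this position is also open.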